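Swapping a Nitrile for an Acid on a Branched Chain

This account rests on a few compounds, and the source may have more. Where it says the series, first, only, none or still open, it means among the compounds named here.

Two compounds with a shared core, each bearing an acetyl group, a phenol and an ether chain, have been measured so far. Compound 1 `CCCCCc1cc(C(C)=O)c(O)cc1OCCCCC#N` ends its chain in a nitrile on a straight chain. In an assay on isolated protein for binding affinity to leukotriene B4 receptor 1 (Homo sapiens), tested at 1 uM (a higher number here means more inhibition at the concentration tested (going by the name of the read-out), a lower number less inhibition), compound 1 gives 14%. Compound 2 `CCc1cc(C(C)=O)c(O)cc1OCCCC(C)(C)C#N` carries a shorter group on the core and a branched chain ending in a nitrile. In this assay compound 2 gives 46%. Of the two numbers, compound 2 stands highest; the nearest, compound 1, lies lower by a margin beyond the usual scatter, though the two differ in more than one place, so no single change can be read from that gap.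

Compound 3 `CCc1cc(C(C)=O)c(O)cc1OCCCC(C)(C)C(=O)O` has not been measured. It differs from compound 2 in one place: carboxy in place of cyano on a saturated chain carbon bound to three saturated chain carbons. Among the compounds with values here, no measured pair shows this change, so no step size is known from the data. The step from compound 2 to compound 3 is expected to be upward, a number 19 percentage points higher from compound 2 to compound 3 (beyond the scatter), beyond the scatter. Compound 3 is therefore expected to give 65% in this assay, with a range of 35% to 90%.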

Compound 3, a percentage reported as inhibition, at one concentration (the size of the read-out at that concentration, not a potency): 43%
Estimate against measurement, compound 3: 22 percentage points above; low and high end bracket the measured number.
By their numbers in this assay, from the lowest: compound 1; then compounds 3 and 2 (each within the scatter of the next).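

On a saturated chain carbon bound to three saturated chain carbons, carboxy in place of cyano gives, in this assay, a number 3 percentage points lower from compound 2 to compound 3 (within the scatter). Within the data shown here, this is the first comparison that isolates one change, which the gap between compound 1 and compound 2 could not do, and at this place the two end groups cannot be told apart by this read-out at the single concentration tested. The change replaces a cyano group with 2 heavy atoms and 0 hydrogen-bond donors with a carboxy group with 3 heavy atoms and 1 hydrogen-bond donor, yet the two numbers stay within the usual scatter of each other, and nothing measured here speaks to why.

As far as these compounds go, whether an amide or a hydroxymethyl group at the end of this branched chain would fit the same picture remains open, as does the effect of a longer chain carrying the same carboxy group. From the compounds shown here alone, it is also open whether the same swap would give a similar step on the straight chain of compound 1, or whether the result holds only for the branched 1-carboxy-1-methylethyl arrangement.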